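The source may hold more compounds than are shown below. What is called first, only, known or untested is meant among the compounds shown, and "the series" means these compounds.

Among the compounds with values here, only two compounds have been tested so far in a functional assay on the whole organism (strain Kunming) with Mus musculus as the target, with a stated time of 0.5 h (on this read-out lower numbers stand for an effect already at smaller amounts and higher numbers for an effect only at larger amounts of compound), and they share one core. There compound 1 `COc1ccccc1/C=C/C(=O)OC/C=C/c1cc(OC)c(OC)cc1OC` gives 39 mg/kg and compound 2 `COc1cc(OC)c(OC)cc1/C=C/COC(=O)/C=C/c1ccc(Br)cc1` gives 61.8 mg/kg as its dose. These two numbers lie within the usual scatter of each other, so compound 2 cannot be ranked apart from compound 1.

Compound 3 `COc1cc(OC)c(OC)cc1/C=C/COC(=O)/C=C/c1ccccc1C(F)(F)F` keeps the core of compound 2 and alters one group on a double-bonded chain carbon bound to a double-bonded chain carbon. The change is 2-(trifluoromethyl)phenyl in place of 4-bromophenyl on a double-bonded chain carbon bound to a double-bonded chain carbon and nothing else differs.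

Within the data shown here, one measured step bears on this, a swap at the same place of 4-bromophenyl for 2-methoxyphenyl. It amounted to a 1.6-fold higher number from compound 1 to compound 2 (0.20 log units; within the scatter) and so stayed within the scatter. Among the measured compounds shown here, no tested compound carries the 2-(trifluoromethyl)phenyl group, so this single step is thin evidence. On that basis no step beyond the scatter is expected here.

The estimated step is a 1.2-fold lower number from compound 2 to compound 3 (0.09 log units; within the scatter) and it would leave the two compounds indistinguishable. For compound 3 the expected value is 50 mg/kg with an estimated range from 24 mg/kg to 105 mg/kg in this test.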

Compound 3, dose for half-maximal effect: 85.7 mg/kg
Compound 3: middle estimate off by 1.7-fold (0.23 log units), on the low side; low and high end bracket the measured number.
By their numbers in this assay, from the lowest: compounds 1, 2 and 3 (each within the scatter of the next, the first and the last beyond it).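

In this assay, putting 2-(trifluoromethyl)phenyl in place of 4-bromophenyl on a double-bonded chain carbon bound to a double-bonded chain carbon gives a 1.4-fold higher number from compound 2 to compound 3 (0.14 log units; within the scatter), so this second swap at the position also leaves the two compounds indistinguishable. Within the data shown here, the pair of compounds at the ends of the series now gives the first step beyond the scatter, a 2.2-fold higher number from compound 1 to compound 3 (0.34 log units; beyond the scatter), with trifluoromethyl in place of methoxy on an aromatic carbon as the only difference, which shows that the choice of group here can change the dose needed, though only modestly. Nothing available explains why these two groups differ in this way.

Among these compounds, with only three compounds, and a single step that only just clears the scatter, it remains open whether the difference between methoxy and trifluoromethyl would hold up with further examples at this position. From the compounds shown here alone, it is also open how the dose would respond to a phenyl ring carrying an amine or a carboxylic acid, or to a longer chain in place of the ring.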